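The compounds below may be only part of what the source reports. "The series", "measured", "known", "first", "only" and "open" are said of these compounds alone.

Measured compounds in a functional assay on Chem-1 cells for antagonist activity at C-X-C chemokine receptor type 4 (Homo sapiens), read by calcium flux; a lower number here means a stronger inhibitor, a higher number a weaker inhibitor:
compound 1 `NCCCCN(C[C@@H]1CN(C(=O)c2ccco2)CCN1)[C@H]1CCCc2cccnc21` gives 35 nM
compound 2 `NCCCCN(C[C@H]1CN(C(=O)OCc2ccccc2)CCN1)[C@H]1CCCc2cccnc21` gives 18 nM
compound 3 `NCCCCN(C[C@H]1CN(S(=O)(=O)c2cc3ccccc3s2)CCN1)[C@H]1CCCc2cccnc21` gives 39 nM

All three share the same core and differ only in the group carried on the ring nitrogen of that core. Compound 2 has the lowest number of the three in this assay. Its nearest neighbour is compound 1, whose number is higher by an amount that stays within the scatter, so the two cannot be ordered. Compound 3 has a number higher than that of compound 2 by an amount just beyond the scatter.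

The next compound, compound 4 `NCCCCN(C[C@H]1CN(C(=O)Nc2ccccc2)CCN1)[C@H]1CCCc2cccnc21`, is compound 2 with anilino in place of benzyloxy on a carbonyl carbon. The carbamate becomes a urea while the aromatic ring is kept. Among the compounds with values here, no pair of measured compounds shows this change, so its direction in this assay is not known from the series. The three measured groups on this ring nitrogen, though quite different from each other, all give numbers within a narrow band, which suggests that the step from compound 2 to compound 4 will be small. The estimate is therefore a step of a 1.4-fold higher number from compound 2 to compound 4 (0.14 log units; within the scatter), not beyond the scatter, and compound 4 is expected to give about 25 nM in this assay, with a likely range from 8 nM to 80 nM.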

Compound 4, half-maximal inhibitory concentration: 21000 nM
For compound 4 the middle estimate is 840-fold (2.92 log units) below the measured one, and the stated range ends below it.
By their numbers in this assay, from the lowest: compounds 2, 1 and 3 (each within the scatter of the next, the first and the last beyond it); then compound 4.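

In this assay, anilino in place of benzyloxy on a carbonyl carbon gives a 1200-fold higher number from compound 2 to compound 4 (3.07 log units; beyond the scatter), so the group on this ring nitrogen is not freely interchangeable, as the three earlier compounds alone might have suggested. One six-membered aromatic ring of carbon only is present in both groups, so keeping that ring and the carbonyl carbon does not by itself preserve the activity of compound 2 in this assay. The change that turns the carbamate into a urea swaps an oxygen for a nitrogen and brings in a hydrogen-bond donor while removing a hydrogen-bond acceptor, but no measurement here gives a reason for the step or singles out one of these differences.

The compounds shown leave open whether the step follows the amide hydrogen of the urea or the way the phenyl ring is attached to the carbonyl carbon. Benzylamino, which has a methylene link like benzyloxy, and N-methylanilino, which has no amide hydrogen, on the same carbonyl carbon would begin to separate these two readings.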